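This account rests on a few compounds, and the source may have more. Where it says the series, first, only, none or still open, it means among the compounds named here.

Measured in a functional assay on HEK293 cells with D(4) dopamine receptor (Homo sapiens) as the target, read by FLIPR; a higher number here means that more compound is needed for the effect, a lower number that less compound is needed:
compound 1 `CO/N=C(\CCN1CCN(c2ccccn2)CC1)c1ccc(Cl)cc1`: 37.6 nM
compound 2 `CO/N=C(\CCN1CCN(c2ccccn2)CC1)c1cc(C)cc(C)c1`: 175 nM
compound 3 `CO/N=C(\CCN1CCN(c2ccccn2)CC1)c1ccc(Cl)cc1Cl`: 249 nM

Compound 1 stands lowest of the three numbers in this assay. Both measured steps away from it run upward: a 4.7-fold higher number from compound 1 to compound 2 (0.67 log units; beyond the scatter) and a 6.6-fold higher number from compound 1 to compound 3 (0.82 log units; beyond the scatter). Between the other two the step is a 1.4-fold higher number from compound 2 to compound 3 (0.15 log units; within the scatter).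

Compound 4 `CO/N=C(/c1ccc(Cl)cc1)C(O)CN1CCN(c2ccccn2)CC1` differs from compound 1 by hydroxy in place of hydrogen on a saturated chain carbon bound to a carbon with a double bond to nitrogen and a saturated chain carbon. Among the compounds with values here, none of the measured steps bears on this change; each of them alters only the aryl group on the carbon with the double bond to nitrogen, and the chain carbon is untouched in all three. The expectation for compound 4 therefore rests on compound 1 alone, with no step beyond the scatter anticipated in either direction, and wide uncertainty. Compound 4 is estimated at 55 nM (range 12 nM to 300 nM). The expected step is a 1.5-fold higher number from compound 1 to compound 4 (0.17 log units; within the scatter).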

Compound 4, half-maximal effective concentration: 22.6 nM
Estimate against measurement, compound 4: 2.4-fold (0.39 log units) above; the measured number falls inside the stated range.
By their numbers in this assay, from the lowest: compounds 4 and 1 (each within the scatter of the next); then compounds 2 and 3 (each within the scatter of the next).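

Hydroxy in place of hydrogen on a saturated chain carbon bound to a carbon with a double bond to nitrogen and a saturated chain carbon leaves the number in this assay within the scatter (a 1.7-fold lower number from compound 1 to compound 4 (0.22 log units; within the scatter)). Within the data shown here, this is the first reading on the chain, and the chain carbon accepts this change without a step beyond the scatter. No supporting data bear on this result.

Open, as far as these compounds go, is whether an amine or a methoxy group on the same carbon, or a longer chain, would behave likewise. Also open, from the compounds shown here alone, is whether hydroxy gives the same outcome with the 2,4-dichlorophenyl or 3,5-dimethylphenyl group.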